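A few compounds are considered here, and "the series" means these few. Any claim that something is new, unique, unknown or untested is made for them only; others in the source may bear on it.

Compound 1 `CCCc1nc2c(C)cc(-c3nc4ccccc4n3C)cc2n1S(=O)(=O)c1ccccc1` stands at the edge of what the assay can report. In a functional assay on HCT-116 cells (Homo sapiens) for cytotoxicity, read by MTT assay (on this read-out lower numbers stand for stronger inhibition and higher numbers for weaker inhibition), compound 1 gives > 50000 nM, which is a limit of the assay and not a number (the limit of > 50000 nM in this assay, at which 1 of the 2 values shown sits). Compound 2 `CCCc1nc2c(C)cc(-c3nc4ccccc4n3C)cc2n1S(=O)(=O)c1ccc(C)cc1` differs from it by a methyl in place of hydrogen on an aromatic carbon, and in this assay compound 2 gives 41600 nM; the step of an at least 1.2-fold lower number from compound 1 to compound 2 (0.07 log units; that floor lies within the scatter) stays within the scatter. Compound 3 `CCCc1nc2c(C)cc(-c3nc4ccccc4n3C)cc2n1S(=O)(=O)c1c(C)cc(C)cc1C` carries 2,4,6-trimethylphenyl in place of phenyl on a sulfonyl sulfur. Within the data shown here, only that single measured step bears on this change, so no movement beyond the scatter is expected in this assay from compound 1 to compound 3. Compound 3 is therefore estimated at 45000 nM, within 20000 nM to 100000 nM, a step of an at least 1.1-fold lower number from compound 1 to compound 3 (0.04 log units; that floor lies within the scatter).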

Compound 3, half-maximal inhibitory concentration: 29900 nM
Compound 3: the middle estimate sits 1.5-fold (0.18 log units) above what was measured, and the stated range covers the measured number.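

Placing 2,4,6-trimethylphenyl on the sulfonyl sulfur gives an at least 1.6-fold lower number from compound 1 to compound 3 (0.22 log units; that floor lies within the scatter), so this heavier substitution of the phenyl ring also produces no step beyond the scatter. Against 4-methylphenyl, the change gives a 1.4-fold lower number from compound 2 to compound 3 (0.14 log units; within the scatter), so the added methyl groups cannot be told apart from the scatter in this assay. The reading for compound 1 remains a limit of the assay and not a number: the limit of > 50000 nM in this assay, at which 1 of the 3 values shown sits.

The compounds shown leave open whether an amine or a carboxylic acid on this aromatic ring would move the number beyond the scatter.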